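Ring Closure of the Amine Side Chain on a Tricyclic Core

A few compounds are considered here, and "the series" means these few. Any claim that something is new, unique, unknown or untested is made for them only; others in the source may bear on it.

Compound 1 `C=CCN(CCC)Cc1c(C(F)(F)F)nc2n(-c3c(C)cc(C)cc3C)c(Cl)cn12`: 4.5 nM
Compound 2 `CCCN(Cc1ccc([N+](=O)[O-])cc1)Cc1c(C(F)(F)F)nc2n(-c3c(C)cc(C)cc3C)c(Cl)cn12`: 150 nM

In an assay on cells for displacement of a labelled ligand from corticotropin-releasing factor receptor 1 (Homo sapiens), with a stated time of 100 min (on this read-out higher numbers stand for weaker inhibition and lower numbers for stronger inhibition), compound 1 gives 4.5 nM, the lowest of the two numbers measured, and in this assay compound 2 gives 150 nM. Among the compounds with values here, the only measured step is a 33-fold higher number from compound 1 to compound 2 (1.52 log units; beyond the scatter), which concerns a different part of the side chain from the change examined here.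

Compound 3 `Cc1cc(C)c(-n2c(Cl)cn3c(CN4CCCC(C)C4)c(C(F)(F)F)nc23)c(C)c1` has not yet been measured. It differs from compound 1 as follows: 3-methylpiperidin-1-yl in place of allyl(propyl)amino on a saturated chain carbon bound to an aromatic carbon. The open chain of compound 1 is thus replaced by a six-membered ring of the same size, attached at the same place.

Within the data shown here, no measured step tests a ring closure of this kind, so the expectation rests only on the position of compound 1 as the strongest measured compound and on the observation that a change at the amine side chain, in the step to compound 2, moved the number a long way. A modest weakening is therefore expected, as a 3.3-fold higher number from compound 1 to compound 3 (0.52 log units; beyond the scatter). The estimate for compound 3 in this assay is 15 nM, with a range from 3 nM to 80 nM.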

Compound 3, inhibition constant: 5800 nM
The estimate for compound 3 lay 390-fold (2.59 log units) below the measured number; measured number above the stated range.
By their numbers in this assay, from the lowest: compound 1; then compound 2; then compound 3.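

In this assay, tying the open allyl(propyl)amino group into a 3-methylpiperidin-1-yl ring gives a 1300-fold higher number from compound 1 to compound 3 (3.11 log units; beyond the scatter), although the two groups contain the same atoms. This position on the saturated chain carbon therefore responds strongly to how those atoms are joined, not only to which atoms are present. The earlier step, a 33-fold higher number from compound 1 to compound 2 (1.52 log units; beyond the scatter), replaced vinyl with the larger 4-nitrophenyl, whereas this bigger step shows that a large loss needs no added atoms, and no measurement shown here explains why the ring has this effect.

A comparison with plain piperidin-1-yl, which has no methyl group, would help separate the effect of closing the ring from that of the methyl group on it. Pyrrolidin-1-yl, with a smaller ring, and dipropylamino, an open chain without the double bond, would show whether ring size or the allyl group also matters at this position.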